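A few compounds are considered here, and "the series" means these few. Any claim that something is new, unique, unknown or untested is made for them only; others in the source may bear on it.

Compound 2 `O=C(O)CNc1cccc(CNc2cc(C(F)(F)F)cc3[nH]ncc23)c1` in an assay for inhibition of Tryptophan 2,3-dioxygenase (Homo sapiens), with stated times of 10 min and 60 min, tested at 100 uM (on this read-out lower numbers stand for a weaker effect and higher numbers for a stronger effect at the one concentration tested), gives 65%. Of the three compounds measured, compound 3 `O=[N+]([O-])c1ccc2[nH]c(CNc3cc(C(F)(F)F)cc4[nH]ncc34)cc2c1` gives 69%, a number within the scatter of compound 2, while compound 1 `O=[N+]([O-])c1cccc(CNc2cc(C(F)(F)F)cc3[nH]ncc23)c1` gives 82%, and the step of a number 17 percentage points lower from compound 1 to compound 2 (beyond the scatter) is the only one that lies beyond the scatter. Compound 4 `O=C(O)c1cccc(CNc2cc(C(F)(F)F)cc3[nH]ncc23)c1` has not yet been measured. It differs from compound 2 in one place: carboxy in place of (carboxymethyl)amino on an aromatic carbon. Among the measured compounds shown here, the only measured step that bears on this position is a number 17 percentage points lower from compound 1 to compound 2 (beyond the scatter), which followed the exchange of nitro for (carboxymethyl)amino. For the measured compounds named here, no measured compound carries a carboxy directly on this ring, so the direction of the new step cannot be read from the data, and a step of roughly that size in either direction, or none beyond the scatter, would fit what is known. On that basis compound 4 is expected to give about 68%, within a range from 50% to 85%. The expected step of a number 3 percentage points higher from compound 2 to compound 4 (within the scatter) is therefore small and uncertain.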

Compound 4, a percentage reported as inhibition, at one concentration (the size of the read-out at that concentration, not a potency): 94%
The estimate for compound 4 lay 26 percentage points below the measured number; the whole stated range lies below it.
By their numbers in this assay, from the lowest: compounds 2 and 3 (each within the scatter of the next); then compound 1; then compound 4.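

Compound 2 and compound 4 both carry a carboxy group, yet moving it directly onto the aromatic carbon gives a number 29 percentage points higher from compound 2 to compound 4 (beyond the scatter) in this assay, so having the group somewhere in this substituent does not settle the read-out. The exchange for nitro gives a number 12 percentage points higher from compound 1 to compound 4 (beyond the scatter), which shows that replacing nitro at this position can raise the number as well as lower it, as it did with (carboxymethyl)amino. Nothing shown here explains why the numbers move this way.

The compounds shown leave open whether the amine nitrogen or the longer chain in (carboxymethyl)amino goes with the lower number; a carboxymethyl group without that nitrogen would separate the two. Going by these compounds, it also remains open whether an amide in place of the carboxy would keep the high number.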